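The source may hold more compounds than are shown below. What is called first, only, known or untested is meant among the compounds shown, and "the series" means these compounds.

Measured so far:
compound 1, `CCCCCCCCC(=O)N1c2ccccc2CCC1C(=O)Nc1ccccc1C(F)(F)F` — 7700 nM
compound 2, `O=C(Nc1cc(C(F)(F)F)cc(C(F)(F)F)c1)C1CCc2ccccc2N1C(=O)c1cccc(Cl)c1` — 625 nM

In a functional assay on HCT-15 cells (Homo sapiens) for cytotoxicity, read by sulforhodamine B assay, with a stated time of 72 h (on this read-out lower numbers stand for stronger inhibition of growth and higher numbers for weaker inhibition of growth), compound 2 gives 625 nM, the lowest of the two numbers; compound 1 gives 7700 nM, a higher number that lies beyond the scatter. Compound 3, `O=C(Nc1cc(C(F)(F)F)cc(C(F)(F)F)c1)C1CCc2ccccc2N1C(=O)c1ccccc1`, differs from compound 2 in one place: hydrogen in place of chloro on an aromatic carbon. Among the compounds with values here, no step between measured compounds covers this change, so the expectation rests on compound 2 alone. A small loss is expected, and the estimated step of a 1.8-fold higher number from compound 2 to compound 3 (0.25 log units; within the scatter) should sit within or just beyond the scatter. Compound 3 is accordingly estimated at 1100 nM, with a range of 400 nM to 3500 nM.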

Compound 3, concentration for 50% growth inhibition: 3540 nM
Beside the measured number, compound 3's estimate is 3.2-fold (0.51 log units) below it, and the stated range ends below it.
By their numbers in this assay, from the lowest: compound 2; then compound 3; then compound 1.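

In this assay, within the data shown here, the change from 3-chlorophenyl to phenyl gives a 5.7-fold higher number from compound 2 to compound 3 (0.75 log units; beyond the scatter) and so is the first one-place comparison. It shows that the chloro on this aromatic carbon counts for more than the scatter, at least in this one pair. Nothing available explains the size of this step.

Going by these compounds, whether fluoro, methoxy or an amine on this carbon would match chloro stays open. So does whether chloro would count the same on another carbon of this ring.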